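The compounds below may be only part of what the source reports. "The series", "measured", "known", "first", "only" and "open" are said of these compounds alone.

Of the compounds shown here, three built on one shared core have been tested in a functional assay on OVCAR-4 cells (Homo sapiens) for inhibition, read by sulforhodamine B assay, with a stated time of 48 h; a lower number here means a stronger inhibitor of growth, a higher number a weaker inhibitor of growth. Compound 1 `Nc1cc(N)c2nc(-c3ccccc3)c(NCc3ccc(Cl)c(Cl)c3)nc2c1` gives 11700 nM. Compound 2 `COc1ccc(CNc2nc3cc(N)cc(N)c3nc2-c2ccccc2)cc1OC` gives 2690 nM, and compound 3 `Nc1cc(N)c2nc(-c3ccccc3)c(NCc3ccc(F)cc3)nc2c1` gives 1700 nM. On these numbers compound 3 lies clearly apart from compound 1, as a 6.9-fold lower number from compound 1 to compound 3 (0.84 log units; beyond the scatter) shows, whereas a 1.6-fold lower number from compound 2 to compound 3 (0.20 log units; within the scatter) is within the scatter, so compound 3 and compound 2 cannot be told apart. Compound 4 `Nc1cc(N)c2nc(-c3ccccc3)c(Oc3ccc(F)cc3)nc2c1` differs from compound 3 in a single place: 4-fluorophenoxy in place of (4-fluorobenzyl)amino on an aromatic carbon. Among the compounds with values here, none of the measured steps covers a change of this kind; each of them only swaps the substituted ring at the end of the (4-fluorobenzyl)amino group, and even the largest of them, a 6.9-fold lower number from compound 1 to compound 3 (0.84 log units; beyond the scatter), remained modest, as did a 4.3-fold lower number from compound 1 to compound 2 (0.64 log units; beyond the scatter). There is thus no measured basis for a large move in either direction. The expected step in this assay is therefore a 1.8-fold higher number from compound 3 to compound 4 (0.25 log units; within the scatter), carried with wide uncertainty. Compound 4 is estimated at 3000 nM, within a range from 800 nM to 12000 nM.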

Compound 4, concentration for 50% growth inhibition: 8320 nM
Estimate against measurement, compound 4: 2.8-fold (0.44 log units) below, and the stated range covers the measured number.
By their numbers in this assay, from the lowest: compounds 3 and 2 (each within the scatter of the next); then compounds 4 and 1 (each within the scatter of the next).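

Within the data shown here, until now, only the substituted ring at the end of the side group had changed; compound 4 is the first to change how that ring is attached to the shared core. In this assay, 4-fluorophenoxy in place of (4-fluorobenzyl)amino on this aromatic carbon gives a 4.9-fold higher number from compound 3 to compound 4 (0.69 log units; beyond the scatter), so the link itself, and not only the ring, affects the read-out. The swap also alters two things at once, since the entering group has no hydrogen-bond donor and lacks the chain carbon, and nothing available explains the direction of the step.

Which of these two differences carries the step remains open; a 4-fluoroanilino group or a 4-fluorobenzyloxy group at this carbon would separate them. Also open, on these data alone, is whether a 3,4-dimethoxyphenoxy or 3,4-dichlorophenoxy group would follow the ring order seen with the amine link.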